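This account rests on a few compounds, and the source may have more. Where it says the series, first, only, none or still open, it means among the compounds named here.

Measured compounds: compound 1 `CC(C)c1ccc(-c2nc(SCc3cn(CC(=O)NC(=O)Nc4ccccn4)nn3)nc(Nc3ccc(Cl)cc3)c2C#N)cc1` gives 860 nM in a functional assay on B16-F10 cells (Mus musculus) for inhibition, read by MTT assay, with a stated time of 72 h; on this read-out higher numbers stand for weaker inhibition and lower numbers for stronger inhibition; compound 2 `CC(C)c1ccc(-c2nc(SCc3cn(CC(=O)NC(=O)Nc4ccccn4)nn3)nc(Nc3ccccc3F)c2C#N)cc1` gives 8380 nM; compound 3 `CC(C)c1ccc(-c2nc(SCc3cn(CC(=O)NC(=O)Nc4ccccn4)nn3)nc(Nc3ccccc3)c2C#N)cc1` gives 14300 nM.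

Compound 3 shows the highest number of the three, beyond the scatter from compound 1 but within it of compound 2. Compound 4 `CC(C)c1ccc(-c2nc(SCc3cn(CC(=O)NC(=O)Nc4ccccn4)nn3)nc(Nc3ccccc3O)c2C#N)cc1` differs from compound 3 by hydroxy in place of hydrogen on an aromatic carbon. The step that bears on it most directly is the reverse of the change from compound 2 to compound 3, where fluoro left the same position a 1.7-fold higher number from compound 2 to compound 3 (0.23 log units; within the scatter); the chloro-to-hydrogen step a 17-fold higher number from compound 1 to compound 3 (1.22 log units; beyond the scatter) was larger but sits elsewhere on the ring. A hydroxy entering at that position is therefore expected to move the number little, if at all, beyond the scatter: a 1.5-fold lower number from compound 3 to compound 4 (0.18 log units; within the scatter). Compound 4 is estimated at 9500 nM, ranging from 4000 nM to 25000 nM.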

Compound 4, half-maximal inhibitory concentration: 16100 nM
Compound 4: middle estimate off by 1.7-fold (0.23 log units), on the low side; low and high end bracket the measured number.
By their numbers in this assay, from the lowest: compound 1; then compounds 2, 3 and 4 (each within the scatter of the next).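

In this assay, hydroxy on the aromatic carbon ortho to a large group leaves the number indistinguishable from that with hydrogen (a 1.1-fold higher number from compound 3 to compound 4 (0.05 log units; within the scatter)) and with fluoro (a 1.9-fold higher number from compound 2 to compound 4 (0.28 log units; within the scatter)). Hydrogen, fluoro and hydroxy thus fall within the scatter of one another here, while the 4-chlorophenyl of compound 1 stays clearly apart (a 19-fold higher number from compound 1 to compound 4 (1.27 log units; beyond the scatter)). No measurement shown accounts for this flat result.

Going by these compounds, whether an amine or a methoxy at this same carbon would separate from these groups stays open. So does whether hydroxy would match chloro where compound 1 carries it.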